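A few compounds are considered here, and "the series" means these few. Any claim that something is new, unique, unknown or untested is made for them only; others in the source may bear on it.

Three compounds share one core and differ only in the group on the six-membered aromatic ring of carbon only. Compound 1 `O=C(Nc1ccccc1)C1CCN(C/C=C/c2ccccc2)CC1` carries only hydrogen there, and in a functional assay on HepG2 cells (Homo sapiens) for inhibition, read by MTT assay, with a stated time of 72 h (a lower number here means a stronger inhibitor, a higher number a weaker inhibitor), compound 1 gives 90900 nM. Compound 2 `CCCCc1ccc(NC(=O)C2CCN(C/C=C/c3ccccc3)CC2)cc1` carries a butyl group, and in this assay compound 2 gives 4320 nM, the lowest of the three numbers. Compound 3 `COc1cccc(NC(=O)C2CCN(C/C=C/c3ccccc3)CC2)c1` carries a methoxy group, and in this assay compound 3 gives 78600 nM, close to compound 1. The step of a 21-fold lower number from compound 1 to compound 2 (1.32 log units; beyond the scatter) is large, while the step of a 1.2-fold lower number from compound 1 to compound 3 (0.06 log units; within the scatter) stays within the scatter, so the butyl group accounts for the whole gain seen so far. Compound 4 `N#Cc1ccc(NC(=O)C2CCN(C/C=C/c3ccccc3)CC2)cc1` is not yet measured. It differs from compound 2 by cyano in place of butyl on an aromatic carbon. Taking away the butyl group removes the one change that has lowered the number, and the other small group tried, in compound 3, did nothing beyond the scatter. Compound 4 is therefore expected to give up most of that gain, a step of about a 12-fold higher number from compound 2 to compound 4 (1.06 log units; beyond the scatter). The estimated value for compound 4 is 50000 nM, with a likely range from 15000 nM to 150000 nM.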

Compound 4, half-maximal inhibitory concentration: 38300 nM
For compound 4 the middle estimate is 1.3-fold (0.12 log units) above the measured one; the measured number falls inside the stated range.
By their numbers in this assay, from the lowest: compound 2; then compound 4; then compounds 3 and 1 (each within the scatter of the next).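

In this assay the swap of butyl for cyano on the aromatic carbon para to a large group gives an 8.9-fold higher number from compound 2 to compound 4 (0.95 log units; beyond the scatter) and so loses most of the gain that butyl brought. Cyano still differs from hydrogen at this place, with a 2.4-fold lower number from compound 1 to compound 4 (0.38 log units; beyond the scatter) as a modest step beyond the scatter, and the change from 3-methoxyphenyl to 4-cyanophenyl gives a 2.1-fold lower number from compound 3 to compound 4 (0.31 log units; beyond the scatter) as another modest step, so a group much shorter than butyl can also lower the number, though far less. Nothing measured here explains why butyl and cyano differ in this way.

Still open, as far as these compounds go, is whether a longer chain such as hexyl would lower the number further, or a shorter one such as ethyl would keep part of the gain. From the compounds shown here alone, how an amine or a carboxylic acid at this place would compare with cyano also remains unknown.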